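Moving the Methyl Around the Small Ring

The source may report more compounds than this note shows. Statements on the series, on what has been measured and on what is new or still open speak of the compounds shown alone.

Measured so far in an assay on HEK293 cells for activation of Kir3.1/Kir3.2 (Homo sapiens), read by thallium flux; on this read-out higher numbers stand for larger maximal responses and lower numbers for smaller maximal responses:
Compound 1 `Cc1cc(NC(=O)Cn2nnc(-c3ccccc3)n2)n(C2CCCCC2)n1` gives 92% in this assay.
Compound 3 `CC1CC1c1cc(NC(=O)Cn2nnc(-c3ccccc3)n2)n(C2CCCCC2)n1` gives 78% in this assay.
Compound 2 `Cc1cc(NC(=O)Cn2nnc(-c3ccccc3)n2)n(C2CCC(C)(C)CC2)n1` gives > 19% in this assay, which is a limit of the assay and not a number.

Compound 3 stands lowest of the two numbers; its nearest neighbour is compound 1, with a number 14 percentage points lower from compound 1 to compound 3 (beyond the scatter) between them. The unmeasured compound 4 `CC1(c2cc(NC(=O)Cn3nnc(-c4ccccc4)n3)n(C3CCCCC3)n2)CC1` differs from compound 3 in one place: 1-methylcyclopropyl in place of 2-methylcyclopropyl on an aromatic carbon. Going by the values given here, no measured step moves a methyl around the same three-membered ring. The step of a number 14 percentage points lower from compound 1 to compound 3 (beyond the scatter), where 2-methylcyclopropyl replaced methyl on an aromatic carbon, was modest, and the step that the limit leaves unreadable from compound 1 to compound 2 gives no readable size. Since the ring itself stays, only a change within the scatter is expected in this assay, namely no change at the digits printed from compound 3 to compound 4 (within the scatter) in the expected outcome. Compound 4 is therefore estimated at 78% with a range from 60% to 95% around it.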

Compound 4, largest response reached (Emax), in percent of the reference or control that the assay uses: > 10%
Compound 4 was reported as a limit; the forecaster's own chance of this, stated with the estimate: 10%; the middle value lies beyond the limit too.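

Compound 4 gives > 10%, which is a limit and not a number, so its steps from compound 1 and compound 3 cannot be read. From the compounds shown here alone, whether moving the methyl around the three-membered ring changes the maximal response stays open.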